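Sulfonyl series: hexyl to cyclohexyl on the chain

The source may hold more compounds than are shown below. What is called first, only, known or untested is meant among the compounds shown, and "the series" means these compounds.

Measured so far in a functional assay, read by fluorescence and spectrophotometry, with a stated time of 1 h (a lower number here means that less compound is needed, a higher number that more compound is needed for the effect), as half-maximal effective concentration
- compound 1 `CCCCCCCCCCCCS(=O)(=O)/C=C/c1ccc(O)c(O)c1` gives 8500 nM
- compound 2 `O=S(=O)(/C=C/c1ccc(O)c(O)c1)CC1CCC1` gives 8800 nM
- compound 3 `CCCCCCCCCS(=O)(=O)/C=C/c1ccc(O)c(O)c1` gives 7700 nM

Compound 3 lies within the scatter of both compound 1 and compound 2, so no order can be read among the three. The next compound, compound 4 `O=S(=O)(/C=C/c1ccc(O)c(O)c1)CCCC1CCCCC1`, has cyclohexyl in place of hexyl on a saturated chain carbon, three bonds along the chain from a sulfonyl sulfur on a saturated chain carbon, three bonds along the chain from a sulfonyl sulfur. For the measured compounds named here, the only measured step that bears on this is a 1.1-fold lower number from compound 1 to compound 3 (0.04 log units; within the scatter) with hydrogen in place of propyl on the chain, and it stays within the scatter. Compound 2 carries a ring in its chain, yet its value (8800 nM) also sits within the scatter of compound 3 (7700 nM). Going by the values given here, no measured compound carries cyclohexyl, so the range stays wide. In this assay no change beyond the scatter is expected. The estimated step of a 1.0-fold higher number from compound 3 to compound 4 (0.02 log units; within the scatter) is expected to be small. The value expected for compound 4 is 8000 nM with an estimated range of 4500 nM to 14000 nM for repeated measurements.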

Compound 4, half-maximal effective concentration: 7900 nM
Compound 4: the middle estimate sits 1.0-fold (0.01 log units) above what was measured; measured number inside the range.
By their numbers in this assay, from the lowest: compounds 3, 4, 1 and 2 (each within the scatter of the next).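

In this assay, cyclohexyl in place of hexyl on a saturated chain carbon, three bonds along the chain from a sulfonyl sulfur, gives a 1.0-fold higher number from compound 3 to compound 4 (0.01 log units; within the scatter) and so stays within the scatter. This is the first step shown in which a one-place change brings a ring into the chain: with 6 heavy atoms, all carbon, on both sides, a six-membered non-aromatic ring of carbon only does not move the number beyond the scatter at this place. No evidence is at hand to explain this result.

The compounds shown carry only carbon in the group at this place, so an amine or a carboxylic acid on the chain remains open. Also open, on these data alone, is whether a phenyl ring in place of cyclohexyl would give a step beyond the scatter.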